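The source may hold more compounds than are shown below. What is called first, only, known or untested is meant among the compounds shown, and "the series" means these compounds.

Working notes on the series. In a functional assay on A549 cells (Homo sapiens) for antiproliferative activity, read by MTT assay, with a stated time of 72 h (on this read-out lower numbers stand for stronger inhibition and higher numbers for weaker inhibition), compound 1 `CCC/C=C/C(=O)Nc1cccc(Oc2nc(Nc3cccc(OC)c3)nc3c2CSCC3)c1` gives 11800 nM, compound 2 `COc1cccc(Nc2nc3c(c(Oc4cccc(NC(=O)C=C(C)C)c4)n2)CSCC3)c1` gives 19800 nM and compound 3 `C=C(F)C(=O)Nc1cccc(Oc2nc(Nc3cccc(OC)c3)nc3c2CSCC3)c1` gives 29600 nM. Compound 2 lies within the scatter of both others, with a 1.7-fold higher number from compound 1 to compound 2 (0.22 log units; within the scatter) and a 1.5-fold higher number from compound 2 to compound 3 (0.17 log units; within the scatter). Only a 2.5-fold higher number from compound 1 to compound 3 (0.40 log units; beyond the scatter) goes beyond the scatter, and modestly.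

Compound 4 `CC(C)=CC(=O)Nc1cccc(Oc2nc(Nc3cccc(C#N)c3)nc3c2CSCC3)c1` differs from compound 2 as follows: cyano in place of methoxy on an aromatic carbon. Cyano replaces methoxy on an aromatic carbon, meta to a large group. All three measured steps change the group on the carbonyl carbon, so none tests this position directly. On these data alone, they show only a narrow span of values, and the direction in this assay remains open. The estimated change is small, a 1.2-fold lower number from compound 2 to compound 4 (0.07 log units; within the scatter), with no step beyond the scatter expected. Compound 4 is expected at 17000 nM, with an estimated range of 6000 nM to 45000 nM.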

Compound 4, half-maximal inhibitory concentration: 36900 nM
The estimate for compound 4 lay 2.2-fold (0.34 log units) below the measured number; the range from low to high includes it.
By their numbers in this assay, from the lowest: compounds 1, 2, 3 and 4 (each within the scatter of the next, the first and the last beyond it).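

Among these compounds, this is the first direct test of this position: going from (3-methoxyphenyl)amino to (3-cyanophenyl)amino in this assay gives a step within the scatter (a 1.9-fold higher number from compound 2 to compound 4 (0.27 log units; within the scatter)). Cyano in place of methoxy on this aromatic carbon therefore cannot be told apart from methoxy in this read-out. No available evidence accounts for the result.

On these data alone, whether an amine or a carboxylic acid at this position would give a step beyond the scatter remains open. As far as these compounds go, it is also open whether the same change reads alike with pent-1-en-1-yl or 1-fluoroethenyl on the carbonyl carbon.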